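Hydrazide replacement at the furazan amine: compound 4

A few compounds are considered here, and "the series" means these few. Any claim that something is new, unique, unknown or untested is made for them only; others in the source may bear on it.

Measured so far in an assay on isolated protein for inhibition of Indoleamine 2,3-dioxygenase 1 (Homo sapiens), read by fluorescence, with a stated time of 60 min; on this read-out lower numbers stand for stronger inhibition and higher numbers for weaker inhibition:
compound 1 `CS(=O)(=O)NNc1nonc1/C(=N/O)Nc1ccc(F)c(Br)c1`, 609 nM;
compound 2 `N=S1(=O)CC(Nc2nonc2/C(=N/O)Nc2ccc(F)c(Br)c2)C1`, 208 nM;
compound 3 `O=S(=O)(CCNc1nonc1/C(=N/O)Nc1ccc(F)c(Br)c1)NCC1CC1`, 312 nM.

Compound 1 stands highest of the three numbers in this assay. Its nearest neighbour is compound 3, whose value sits within the scatter of that of compound 1; its furthest is compound 2, reached by a 2.9-fold lower number from compound 1 to compound 2 (0.47 log units; beyond the scatter).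

Compound 4 `O=S(=O)(CCNc1nonc1/C(=N/O)Nc1ccc(F)c(Br)c1)NO` is not yet measured. It differs from compound 1 by 2-(hydroxysulfamoyl)ethyl in place of methanesulfonamido on a nitrogen on an aromatic ring. For the measured compounds named here, the one measured step at the same nitrogen, a 2.9-fold lower number from compound 1 to compound 2 (0.47 log units; beyond the scatter), was modest. Compound 3, which also carries a chain with a sulfonamide on that nitrogen, gives a number that does not separate from compound 1 beyond the scatter. On that basis the step for compound 4 is expected to be small and, if anything, toward a lower number, a 1.6-fold lower number from compound 1 to compound 4 (0.20 log units; within the scatter). Compound 4 is therefore estimated at 380 nM, with a range from 150 nM to 950 nM.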

Compound 4, half-maximal inhibitory concentration: 126 nM
For compound 4 the middle estimate is 3.0-fold (0.48 log units) above the measured one, outside the stated range (below it).
By their numbers in this assay, from the lowest: compounds 4, 2, 3 and 1 (each within the scatter of the next, the first and the last beyond it).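

In this assay, 2-(hydroxysulfamoyl)ethyl in place of methanesulfonamido gives a 4.8-fold lower number from compound 1 to compound 4 (0.68 log units; beyond the scatter), so a chain with a sulfonamide on this nitrogen can separate from compound 1 beyond the scatter, which the chain of compound 3 did not do. Hydroxy in place of cyclopropylmethyl on the sulfonamide nitrogen gives a 2.5-fold lower number from compound 3 to compound 4 (0.39 log units; beyond the scatter), so the number depends on what that sulfonamide nitrogen carries and not only on the chain being present. The open chain and the four-membered ring group do not separate, at a 1.7-fold lower number from compound 2 to compound 4 (0.22 log units; within the scatter).

Nothing available explains why hydroxy on the sulfonamide nitrogen goes with the lower number. From the compounds shown here alone, it remains open whether methoxy or an unsubstituted amino group on that sulfonamide nitrogen, or a longer chain carrying the hydroxysulfamoyl group, would keep the number of compound 4.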